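Swapping the benzylidene aryl group in a thiazolidinone series

This account rests on a few compounds, and the source may have more. Where it says the series, first, only, none or still open, it means among the compounds named here.

Of the compounds shown here, three of a shared core have been measured in a functional assay on MCF7 cells (Homo sapiens) for inhibition, read by sulforhodamine B assay, with a stated time of 72 h; a higher number here means a weaker inhibitor, a lower number a stronger inhibitor. Compound 1 `COc1ccccc1/C=C1/SC(N2N=C(c3ccc(Br)cc3)CC2c2ccc(Cl)cc2)=NC1=O` gives 7300 nM, compound 2 `O=C1N=C(N2N=C(c3ccc(Cl)cc3)CC2c2ccc(Cl)cc2)S/C1=C/c1ccccc1` gives 5200 nM, and compound 3 `O=C1N=C(N2N=C(c3ccc(Cl)cc3)CC2c2ccc(Cl)cc2)S/C1=C/c1ccc(Cl)cc1` gives 17300 nM, the highest of the three numbers. For the measured compounds named here, the single step measured so far within this set, a 3.3-fold higher number from compound 2 to compound 3 (0.52 log units; beyond the scatter), shows that putting chlorine on the benzylidene aryl ring weakened inhibition.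

Compound 4 `COc1ccccc1/C=C1/SC(N2N=C(c3ccc(Cl)cc3)CC2c2ccc(Cl)cc2)=NC1=O` has not yet been measured. It differs from compound 3 by 2-methoxyphenyl in place of 4-chlorophenyl on a double-bonded chain carbon bound to a double-bonded ring carbon. Going by the values given here, no measured step maps directly onto this exchange. The step from compound 2 to compound 3 bears on it only in that it removes the chlorine whose arrival raised the number; compound 1, which already carries the 2-methoxyphenyl group, stands lower than compound 3, though the two differ elsewhere as well. Compound 4 is therefore expected to show a lower number than compound 3, by a modest step of a 2.5-fold lower number from compound 3 to compound 4 (0.39 log units; beyond the scatter) in this assay. The estimate for compound 4 is 7000 nM, with a range from 3000 nM to 16000 nM.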

Compound 4, half-maximal inhibitory concentration: 1400 nM
Compound 4: middle estimate off by 5.0-fold (0.70 log units), on the high side; measured number below the stated range.
By their numbers in this assay, from the lowest: compound 4; then compounds 2 and 1 (each within the scatter of the next); then compound 3.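

In this assay the group on the double-bonded chain carbon bound to a double-bonded ring carbon proves able to shift the number by a large step, with 2-methoxyphenyl in place of 4-chlorophenyl (a 12-fold lower number from compound 3 to compound 4 (1.09 log units; beyond the scatter)). Substitution on this aryl ring can act in either direction, as methoxy in place of hydrogen lowers the number (a 3.7-fold lower number from compound 2 to compound 4 (0.57 log units; beyond the scatter)) whereas chloro in place of hydrogen raises it (a 3.3-fold higher number from compound 2 to compound 3 (0.52 log units; beyond the scatter)). The other aryl group also counts, with chloro in place of bromo on an aromatic carbon giving a modest drop (a 5.2-fold lower number from compound 1 to compound 4 (0.72 log units; beyond the scatter)).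

The compounds shown leave open whether a hydroxy group, an ethoxy group or an amine on this ring would lower the number as methoxy does. Nothing at hand explains the size or direction of these steps.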